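Chloro to Bromo on the Benzyl Group of Compound 1

The compounds below may be only part of what the source reports. "The series", "measured", "known", "first", "only" and "open" are said of these compounds alone.

Compound 1 `CCCSc1nc(N/N=C(\C)c2ccccc2O)c2nnn(Cc3ccc(Cl)cc3)c2n1` stands at the top of the two numbers obtained in a functional assay on MGC-803 cells (Homo sapiens) for antiproliferative activity, read by MTT assay, with a stated time of 72 h (a higher number here means a weaker inhibitor, a lower number a stronger inhibitor), where compound 1 gives 7100 nM. The nearest number belongs to compound 3 `COc1cc(/C=N/Nc2nc(SCc3ccccc3)nc3c2nnn3Cc2ccccc2)cc(OC)c1OC`, which gives 1320 nM, a gap beyond the scatter. Compound 2 `CCCSc1nc(N/N=C/c2ccc(C)cc2)c2nnn(Cc3ccccc3)c2n1` reaches only a limit of the assay, > 64000 nM. Compound 4 `CCCSc1nc(N/N=C(\C)c2ccccc2O)c2nnn(Cc3ccc(Br)cc3)c2n1` differs from compound 1 by bromo in place of chloro on an aromatic carbon. Among the measured compounds shown here, no pair among the measured compounds shows this exchange, so the step has no precedent in these data. Compound 4 is expected to give 6000 nM, within a range of 2500 nM to 15000 nM. The step of a 1.2-fold lower number from compound 1 to compound 4 (0.07 log units; within the scatter) is therefore expected to stay within the scatter, with no clear direction.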

Compound 4, half-maximal inhibitory concentration: 11300 nM
The estimate for compound 4 lay 1.9-fold (0.27 log units) below the measured number, within the range that was stated.
By their numbers in this assay, from the lowest: compound 3; then compounds 1 and 4 (each within the scatter of the next). At a limit, above all of these: compound 2.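

In this assay, the exchange of chloro for bromo gives the only one-place step among the compounds shown, a 1.6-fold higher number from compound 1 to compound 4 (0.20 log units; within the scatter), a step that stays within the scatter. On this aromatic carbon, para to a large group, 4-chlorobenzyl and 4-bromobenzyl therefore cannot be told apart in this assay. Nothing shown here bears on a cause for this step.

As far as these compounds go, what stays open is whether a different group on this carbon, such as an amine, a nitrile or a carboxylic acid, would move the number beyond the scatter. From the compounds shown here alone, it is also open whether the same exchange would read alike on a different hydrazone side chain.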